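The compounds below may be only part of what the source reports. "The series", "measured", "known", "first", "only" and "open" are said of these compounds alone.

Compound 2, `O=C(CSc1snnc1-c1ccc(Cl)cc1Cl)Nc1ccccc1[N+](=O)[O-]`, was tested in an ADME assay on MT4 cells (Homo sapiens) for cytotoxicity; a higher number here means that more compound is tolerated, a lower number that less compound is tolerated. In this assay compound 2 gave > 283000 nM, which is a limit of the assay rather than a measured number. Compound 1, `COc1ccc(-c2nnsc2SCC(=O)Nc2ccccc2[N+](=O)[O-])cc1`, differs from compound 2 only in the group attached to the shared core. In this assay compound 1 gave >= 280000 nM, also a limit. The step that the two limits leave unreadable from compound 1 to compound 2 therefore cannot be sized. Compound 2 stands at the limit of > 283000 nM in this assay, at which 1 of the 2 values shown sits. For the measured compounds named here, the only other value shown is the limit of >= 280000 nM in this assay, at which 1 of the 2 values shown sits, that of compound 1, so compound 2 can be neither ranked above nor below it.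

Compound 3, `O=C(CSc1snnc1-c1ccccc1)Nc1ccccc1[N+](=O)[O-]`, is the compound still to be measured in this assay. Compared with compound 2 it carries phenyl in place of 2,4-dichlorophenyl on an aromatic carbon. Going by the values given here, the only measured step that bears on this change is the one from compound 1 to compound 2, and that step is unreadable, so no direction beyond the scatter can be drawn from it. The expected change in this assay is a number no higher from compound 2 to compound 3 (the limit leaves the size open), which is expected to lie within the scatter. Compound 3 is estimated at 280000 nM, expected between 100000 nM and 400000 nM, and most likely reported again only as a limit.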

Compound 3, half-maximal cytotoxic concentration: >= 246000 nM
Compound 3 was reported as a limit (the forecaster's own chance of this, stated with the estimate: 75%); the middle value does not contradict the limit.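

In this assay, for the compounds shown here, compound 1, compound 2 and compound 3 are each reported only as a limit, so no step between them can be read. The compounds shown leave open whether phenyl, 2,4-dichlorophenyl and 4-methoxyphenyl differ at all in this assay, and at what concentration any of the three compounds would harm the cells.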